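This account rests on a few compounds, and the source may have more. Where it says the series, first, only, none or still open, it means among the compounds named here.

Working notes on the series. In a functional assay on Huh-7 cells (Homo sapiens) for inhibition, read by MTT assay, with a stated time of 72 h (a higher number here means a weaker inhibitor, a lower number a stronger inhibitor), compound 1 (`Nc1nc2cc(-c3nn(CCCCC(=O)NO)c4ncnc(N)c34)ccc2o1`) gives 9220 nM and compound 2 (`Nc1nc2cc(-c3nn(CCCCCC(=O)NO)c4ncnc(N)c34)ccc2o1`) gives 9910 nM. Among the compounds with values here, compound 2 therefore stands level with compound 1, the only other measured member, and the two values lie within the scatter of each other.

Compound 3 (`CNC(=O)CCCCCCCn1nc(-c2ccc3oc(N)nc3c2)c2c(N)ncnc21`) is still to be measured in this assay. Its difference from compound 2 is 2-(methylcarbamoyl)ethyl in place of hydroxycarbamoyl on a saturated chain carbon, five bonds along the chain from an aromatic nitrogen. In words, this is 2-(methylcarbamoyl)ethyl in place of hydroxycarbamoyl on a saturated chain carbon, five bonds along the chain from an aromatic nitrogen.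

Within the data shown here, only one measured step bears on this: a 1.1-fold higher number from compound 1 to compound 2 (0.03 log units; within the scatter). There, (hydroxycarbamoyl)methyl replaces hydroxycarbamoyl and the hydroxycarbamoyl end stays in place, so that step speaks only to a longer chain. Among the measured compounds shown here, no measured compound lacks the hydroxycarbamoyl group, so the loss of that group is untested here.

A moderate move towards a weaker inhibitor is expected, though a result within the scatter remains possible. The estimated step is a 1.6-fold higher number from compound 2 to compound 3 (0.21 log units; within the scatter). For compound 3 the estimated value is 16000 nM, with an expected range of 6000 nM to 45000 nM.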

Compound 3, half-maximal inhibitory concentration: 2770 nM
Beside the measured number, compound 3's estimate is 5.8-fold (0.76 log units) above it, outside the stated range (below it).
By their numbers in this assay, from the lowest: compound 3; then compounds 1 and 2 (each within the scatter of the next).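

In this assay, within the data shown here, there is a 3.6-fold lower number from compound 2 to compound 3 (0.55 log units; beyond the scatter) and a 3.3-fold lower number from compound 1 to compound 3 (0.52 log units; beyond the scatter) when the hydroxycarbamoyl end gives way to a methylcarbamoyl end on a longer chain, so the hydroxycarbamoyl group is not needed for inhibition at this level, and compound 3, the one compound without it, has the lowest number of the three. The earlier pair showed only that one added chain carbon left the number within the scatter, whereas this change moves it beyond the scatter, with the new end and the longer chain entering together, so the step cannot be divided between them. No evidence is available on what lies behind the lower number.

A hydroxycarbamoyl end on the chain of compound 3, or a methylcarbamoyl end on the chain of compound 2, would separate the two parts of the change. As far as these compounds go, it also remains open whether a carboxylic acid, a primary amide or a still longer chain at this position would keep the lower number.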